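A few compounds are considered here, and "the series" means these few. Any claim that something is new, unique, unknown or untested is made for them only; others in the source may bear on it.

Series notes. Compound 1 `COc1ccc2oc(-c3cn4nc(OC)sc4n3)cc2c1` carries the least substitution on the shared core and gives 30% in an ADME assay on microsomes from liver (Homo sapiens) for metabolic stability, with a stated time of 10 min; a lower number here means that less of the compound is left, a higher number that more of the compound is left. Compound 2 `COc1cc(OCc2cccc(COc3ccccc3)c2)c2cc(-c3cn4nc(OC)sc4n3)oc2c1` gives 86% in this assay, the second highest of the three numbers. Compound 3 `COc1cc(OCc2ccccc2OCc2ccccc2)c2cc(-c3cn4nc(OC)sc4n3)oc2c1` gives 94% in this assay; compound 2 and compound 3 lie within the scatter of each other, while compound 1 stands well below compound 2, a gap beyond the scatter. Among the measured compounds shown here, no step between measured compounds that differ in only one place is available in this set. Compound 4 `COc1cc(OCc2cccc(C#N)c2)c2cc(-c3cn4nc(OC)sc4n3)oc2c1` is not yet measured in this assay. It differs from compound 2 by cyano in place of phenoxymethyl on an aromatic carbon. A downward step of moderate size, beyond the scatter, is expected: a number 21 percentage points lower from compound 2 to compound 4 (beyond the scatter). This expectation rests on compound 1, which with less substitution on the shared core gives 30%, while compound 2 gives 86%, and compound 4 keeps more of the substitution of compound 2 than compound 1 does. The estimate for compound 4 is 65%, with a range from 40% to 88%.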

Compound 4, percent of the compound remaining: 100%
The estimate for compound 4 lay 35 percentage points below the measured number; the whole stated range lies below it.
By their numbers in this assay, from the lowest: compound 1; then compounds 2, 3 and 4 (each within the scatter of the next, the first and the last beyond it).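

Exchanging phenoxymethyl for cyano on an aromatic carbon, at the place meta to a large group, does not lower the number in this assay; instead, the change gives a number 14 percentage points higher from compound 2 to compound 4 (beyond the scatter) for the percent of compound remaining. A high number at this position therefore does not depend on phenoxymethyl or on the six-membered aromatic ring it carries, and it holds with 2 heavy atoms entering where 8 leave. Nothing at hand accounts for the direction of this step.

Going by these compounds, it remains open whether the high number of compound 4 depends on cyano itself or would hold with another small group at this place, such as methyl, an amine or a carboxylic acid. The compounds shown also leave open whether cyano at any other place on this ring would give a similar number.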